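The source may report more compounds than this note shows. Statements on the series, on what has been measured and on what is new or still open speak of the compounds shown alone.

In a functional assay on HepG2 cells (Homo sapiens) for antiproliferative activity, read by MTT assay, with a stated time of 24 h (a lower number here means a stronger inhibitor, a higher number a weaker inhibitor), compound 1 `Cc1ccc(-c2nn(-c3ccccc3)cc2-c2nc3ccccc3n2S(=O)(=O)c2ccccc2)cc1` gives 960 nM and compound 2 `Cc1ccc(-c2nn(-c3ccccc3)cc2-c2nc3ccccc3n2S(=O)(=O)c2ccc(C)cc2)cc1` gives 520 nM. Within the data shown here, these are the only two numbers measured so far, and they lie within the usual scatter of each other, so the data show no real difference between them. Compound 3 `Cc1ccc(-c2nn(-c3ccccc3)cc2-c2nc3ccccc3n2S(=O)(=O)c2ccc(F)cc2)cc1` keeps the shared core and alters one group of compound 2: fluoro in place of methyl on an aromatic carbon, para to a large group. Among the measured compounds shown here, only one measured step bears on this place: a 1.8-fold lower number from compound 1 to compound 2 (0.27 log units; within the scatter), methyl in place of hydrogen on an aromatic carbon. For the measured compounds named here, that step stayed within the scatter, and no measured compound carries fluoro, so no large move and no firm direction are expected in this assay. The expected change is small: a 1.3-fold higher number from compound 2 to compound 3 (0.10 log units; within the scatter). For compound 3 the estimated value is 650 nM, with an expected range from 280 nM to 1500 nM.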

Compound 3, half-maximal inhibitory concentration: 5060 nM
Estimate against measurement, compound 3: 7.8-fold (0.89 log units) below; measured number above the stated range.
By their numbers in this assay, from the lowest: compounds 2 and 1 (each within the scatter of the next); then compound 3.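

The position on this aromatic ring is not indifferent to what it carries. Hydrogen and methyl could not be told apart, but replacing methyl with fluoro gives a 9.7-fold higher number from compound 2 to compound 3 (0.99 log units; beyond the scatter) and this step lies beyond the scatter. Fluoro also separates from hydrogen, with a 5.3-fold higher number from compound 1 to compound 3 (0.72 log units; beyond the scatter) and again a step beyond the scatter, so among these three compounds fluoro alone stands out, as the weaker inhibitor in this assay and not merely as a small variation on the other two. No measurement available here explains why this exchange costs so much activity.

On these data alone, it remains open whether the loss is peculiar to fluoro or is shared by other halogens such as chloro or bromo. As far as these compounds go, it is equally open how a methoxy group or a longer chain such as ethyl would behave at this position.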